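Anilino series: a 3-chlorophenyl analogue on the shared core

This account rests on a few compounds, and the source may have more. Where it says the series, first, only, none or still open, it means among the compounds named here.

Measured so far in a functional assay on ECa-109 cells for inhibition, with ECa-109 cell line (Homo sapiens) as the target, read by sulforhodamine B assay; a lower number here means a stronger inhibitor, a higher number a weaker inhibitor:
Compound 1 `O=C1C=C(Nc2ccccc2F)C(=O)c2c1nc1n2[C@H]2OC[C@@H](O)[C@H]2OC1` gives 2760 nM.
Compound 3 `O=C1C=C(Nc2ccc(Br)cc2)C(=O)c2c1nc1n2[C@H]2OC[C@@H](O)[C@H]2OC1` gives 2850 nM.
Compound 2 `COc1ccccc1NC1=CC(=O)c2c(nc3n2[C@H]2OC[C@@H](O)[C@H]2OC3)C1=O` gives only a limit of the assay, > 4000 nM.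

Going by the values given here, compound 2 stands apart from the other two: it is the one compound at the limit of > 4000 nM in this assay, at which 1 of the 3 values shown sits, so no number is known for it. Compound 4 `O=C1C(Nc2cccc(Cl)c2)=CC(=O)c2c1nc1n2[C@H]2OC[C@@H](O)[C@H]2OC1` differs from it at the amine nitrogen: 3-chlorophenyl in place of 2-methoxyphenyl on an amine nitrogen.

Among the compounds with values here, the only measured step between arylamines, a 1.0-fold higher number from compound 1 to compound 3 (0.01 log units; within the scatter), lies within the scatter, so an exchange of one aryl group for another has so far not moved this assay. Within the data shown here, no step starts from a methoxyphenyl, and compound 2 offers only a limit, so the expectation rests on compounds 1 and 3. For compound 4 the estimate is 3000 nM, within 1400 nM to 6500 nM. Against the limit, the expected step is an at least 1.3-fold lower number from compound 2 to compound 4 (0.12 log units; that floor lies within the scatter).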

Compound 4, half-maximal inhibitory concentration: 3080 nM
Beside the measured number, compound 4's estimate is 1.0-fold (0.01 log units) below it; the measured number falls inside the stated range.
By their numbers in this assay, from the lowest: compounds 1, 3 and 4 (each within the scatter of the next). At a limit, above all of these: compound 2.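

In this assay, the change from 2-methoxyphenyl to 3-chlorophenyl on the amine nitrogen can be read only as a floor: an at least 1.2-fold lower number from compound 2 to compound 4 (0.11 log units; that floor lies within the scatter). This exchange therefore gives a measured number, 3080 nM for compound 4, on one side of the pair only. Compound 2 remains a limit of the assay, so the full size of the change stays unread: the limit of > 4000 nM in this assay, at which 1 of the 4 values shown sits.

Still open, from the compounds shown here alone, is whether a non-aryl group on this amine nitrogen, such as a longer alkyl chain or a morpholine ring, would shift the number beyond the scatter. Also open, going by these compounds, is what a carboxylic acid or a basic amine on the phenyl ring would do.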